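The source may hold more compounds than are shown below. What is called first, only, known or untested is meant among the compounds shown, and "the series" means these compounds.

Measured compounds:
compound 1, `O=C(O)CCNC(=O)c1ccc(CN(c2ccc(Cl)cc2)c2nc(-c3ccc(C(F)(F)F)cc3)cs2)cc1`: 53 nM
compound 2, `O=C(O)CCNC(=O)c1ccc(CN(c2ccc3c(c2)CCC3)c2nc(-c3ccc(C(F)(F)F)cc3)cs2)cc1`: 64 nM

Both values come from an in vitro assay on BHK cells for binding affinity to Glucagon receptor (Homo sapiens); on this read-out higher numbers stand for weaker inhibition and lower numbers for stronger inhibition. Compound 2 stands at one end of these two numbers, yet the step of a 1.2-fold higher number from compound 1 to compound 2 (0.08 log units; within the scatter) is within the scatter, so the two compounds cannot be told apart. Compound 3, `O=C(O)CCNC(=O)c1ccc(CN(c2ccc(OC(F)(F)F)cc2)c2nc(-c3ccc(C(F)(F)F)cc3)cs2)cc1`, is not yet measured; it differs from compound 2 by 4-(trifluoromethoxy)phenyl in place of 2,3-dihydro-1H-inden-5-yl on a nitrogen on an aromatic ring. For the measured compounds named here, the one measured step that bears on this is a swap of the same kind at the same nitrogen, a 1.2-fold higher number from compound 1 to compound 2 (0.08 log units; within the scatter), which changed nothing beyond the scatter. Compound 3 is therefore expected to show a step of a 1.1-fold lower number from compound 2 to compound 3 (0.04 log units; within the scatter), nothing beyond the scatter. The estimate for compound 3 in this assay is 58 nM, with a range from 25 nM to 130 nM.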

Compound 3, half-maximal inhibitory concentration: 51 nM
Compound 3: the middle estimate sits 1.1-fold (0.06 log units) above what was measured, within the range that was stated.
By their numbers in this assay, from the lowest: compounds 3, 1 and 2 (each within the scatter of the next).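

In this assay, the change at this nitrogen on an aromatic ring now gives a 1.3-fold lower number from compound 2 to compound 3 (0.10 log units; within the scatter), so a group holding oxygen and fluorine fares no differently from one of carbon only. Trifluoromethoxy in place of chloro on an aromatic carbon gives a 1.0-fold lower number from compound 1 to compound 3 (0.02 log units; within the scatter), which means that all three groups tried at this place cannot be told apart. No measurement shown here accounts for this sameness.

The compounds shown leave open whether an amine or a hydroxyl on this aromatic ring would move the number beyond the scatter.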